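This account rests on a few compounds, and the source may have more. Where it says the series, first, only, none or still open, it means among the compounds named here.

Working notes on the series built on the shared core of compound 1 `COc1ccc2c(c1)OC(c1cc(OC)c(OC)c(OC)c1)C(C(=O)OCCc1ccccc1)=C2`: one ester, two amides measured, and a third amide still open. In a functional assay for inhibition of nuclear factor NF-kappa-B complex (Homo sapiens) (on this read-out lower numbers stand for stronger inhibition and higher numbers for weaker inhibition), compound 1 gives 16200 nM. Compound 2 `COc1ccc2c(c1)OC(c1cc(OC)c(OC)c(OC)c1)C(C(N)=O)=C2` stands at a limit of the assay, > 50000 nM. Compound 3 `CCNC(=O)C1=Cc2ccc(OC)cc2OC1c1cc(OC)c(OC)c(OC)c1` likewise stands only at a limit, > 50000 nM, so its position is known as a bound, not a number. The step of an at least 3.0-fold higher number from compound 1 to compound 2 (0.48 log units; beyond the scatter) and the step of an at least 3.0-fold higher number from compound 1 to compound 3 (0.48 log units; beyond the scatter) both run from the ester into the region of the limit of > 50000 nM in this assay, at which 2 of the 3 values shown sit. The step that the two limits leave unreadable from compound 2 to compound 3 gives no size to work with.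

Compound 4 `COc1ccc2c(c1)OC(c1cc(OC)c(OC)c(OC)c1)C(C(=O)N(C)OC)=C2` differs from compound 3 in one place: methoxy(methyl)amino in place of ethylamino on a carbonyl carbon. The bearing steps are the two amide steps out of compound 1, each at least modest and toward weaker inhibition; compound 4 keeps an amide on the carbonyl carbon, so no return toward the ester is expected. The step expected is a number no higher from compound 3 to compound 4 (the limit leaves the size open). For compound 4 the estimate in this assay is 50000 nM, with a range of 15000 nM to 200000 nM, most likely reported again only as a limit.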

Compound 4, half-maximal inhibitory concentration: 11700 nM
Compound 4: middle estimate off by 4.3-fold (0.63 log units), on the high side; the measured number lies below the stated range.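

From the compounds shown here alone, compound 4 shows that an amide on this carbonyl carbon need not end at the limit in this assay: the change gives an at least 4.2-fold lower number from compound 3 to compound 4 (0.63 log units; beyond the scatter) and an at least 4.2-fold lower number from compound 2 to compound 4 (0.63 log units; beyond the scatter), and both steps start from a limit, so their true size stays open. The ester does not stand apart from every amide, since methoxy(methyl)amino in place of phenethyloxy gives a 1.4-fold lower number from compound 1 to compound 4 (0.14 log units; within the scatter). The loss seen earlier therefore belongs to the amino and ethylamino amides, not to all amides at this position, and only those two remain at the limit: the limit of > 50000 nM in this assay, at which 2 of the 4 values shown sit.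

Still open, going by these compounds, is whether the recovery follows the missing amide hydrogen or the oxygen of the methoxy group, as both change together here. A dimethylamino group on the same carbonyl carbon would separate the two.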